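A few compounds are considered here, and "the series" means these few. Any claim that something is new, unique, unknown or untested is made for them only; others in the source may bear on it.

Compound 1 `CCN(Cc1ccccc1)C(=O)C1CCN(S(=O)(=O)c2ccc3cn[nH]c3c2)CC1` gives 86% in a functional assay on CHO cells for positive allosteric modulation of muscarinic acetylcholine receptor M5 (Homo sapiens), read by calcium flux; on this read-out higher numbers stand for larger maximal responses and lower numbers for smaller maximal responses.
Compound 2 `CCN(C(=O)C1CCN(S(=O)(=O)c2ccc3cn[nH]c3c2)CC1)[C@H](C)c1ccccc1` gives 87% in this assay.

Among the measured compounds shown here, compound 2 stands highest of the two numbers measured so far, but its nearest neighbour, compound 1, lies only a number 1 percentage points higher from compound 1 to compound 2 (within the scatter) away, a gap within the usual scatter, so the two cannot be told apart on these numbers. The change from compound 1 to compound 2 was a methyl in place of hydrogen on a saturated chain carbon bound to an amide-type nitrogen and an aromatic carbon, and it left the maximal response essentially where it was.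

Compound 3 `CCN(Cc1ccc(F)cc1)C(=O)C1CCN(S(=O)(=O)c2ccc3cn[nH]c3c2)CC1` is not yet measured. It differs from compound 2 by 4-fluorobenzyl in place of 1-phenylethyl on an amide-type nitrogen. For the measured compounds named here, only one measured step touches this part of the molecule, the one from compound 1 to compound 2, and it was within the scatter. Nothing in the data speaks to the fluorine on the benzyl ring. Compound 3 is therefore expected to show a step of a number 2 percentage points lower from compound 2 to compound 3 (within the scatter) in this assay, that is, no change beyond the scatter. The estimate for compound 3 is 85%, expected to fall between 70% and 97%.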

Compound 3, largest response reached (reported as percent of maximum), in percent of the reference or control that the assay uses: 55%
The estimate for compound 3 lay 30 percentage points above the measured number; measured number below the stated range.
By their numbers in this assay, from the lowest: compound 3; then compounds 1 and 2 (each within the scatter of the next).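

In this assay the aromatic ring on the amide-type nitrogen proves sensitive in a way the earlier pair gave no hint of: fluoro in place of hydrogen on an aromatic carbon gives a number 31 percentage points lower from compound 1 to compound 3 (beyond the scatter), whereas methyl on the saturated chain carbon had given only a number 1 percentage points higher from compound 1 to compound 2 (within the scatter). Putting 4-fluorobenzyl in place of 1-phenylethyl on the same nitrogen likewise gives a number 32 percentage points lower from compound 2 to compound 3 (beyond the scatter), so the group at this position can change the maximal response substantially, and a single fluorine is enough to do so when compound 1 is the starting point. Nothing among the available data explains this loss of response.

The compounds shown leave open whether the drop is specific to fluoro or would also follow from chloro, methoxy or a nitrile on that aromatic carbon, and whether fluoro on another aromatic carbon of the ring would have the same result. They also leave open whether methyl on the saturated chain carbon, which made no difference beyond the scatter without the fluoro, would alter the response of 4-fluorobenzyl.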